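The source may hold more compounds than are shown below. What is called first, only, known or untested is meant among the compounds shown, and "the series" means these compounds.

In a functional assay on HT-29 cells (Homo sapiens) for inhibition, read by MTT assay, with a stated time of 72 h (on this read-out higher numbers stand for weaker inhibition and lower numbers for stronger inhibition), three compounds with a shared core have been measured so far. Compound 1 (`COc1ccc(CNCc2c(OC)cc(Oc3cccc(Nc4ccccc4)c3)cc2OC)cc1`) reads 1890 nM and compound 2 (`COc1cc(Oc2cccc(Nc3ccccc3)c2)cc(OC)c1CNCc1ccc(F)cc1`) reads 2750 nM while compound 3 (`COc1cc(Oc2cccc(Nc3ccccc3)c2)cc(OC)c1CNCc1ccc(Cl)cc1`) reads 3350 nM on the same scale. Compound 3 therefore stands level with the other two, as a 1.8-fold higher number from compound 1 to compound 3 (0.25 log units; within the scatter) and a 1.2-fold higher number from compound 2 to compound 3 (0.09 log units; within the scatter) show. The third measured step, a 1.5-fold higher number from compound 1 to compound 2 (0.16 log units; within the scatter), is no larger in kind.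

Compound 4 (`COc1cc(Oc2cccc(Nc3ccccc3)c2)cc(OC)c1CNC1CC1`) carries cyclopropyl in place of 4-chlorobenzyl on an amine nitrogen. The measured steps bear on this only loosely. Each of them exchanges methoxy, fluoro or chloro on an aromatic carbon and keeps the aromatic ring itself, whereas compound 4 loses that ring altogether. Going by the values given here, no measured compound lacks it, so the data do not fix the size of this change.

Among the compounds with values here, the only guide is that compound 3 sits within the scatter of its neighbours, as a 1.2-fold higher number from compound 2 to compound 3 (0.09 log units; within the scatter) shows. On that thin basis no step beyond the scatter is expected in this assay, though the uncertainty is wide. The expected move is a 1.2-fold higher number from compound 3 to compound 4 (0.08 log units; within the scatter) in this reading. The estimated value for compound 4 is 4000 nM (range 1500 nM to 10000 nM).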

Compound 4, half-maximal inhibitory concentration: 12300 nM
Estimate against measurement, compound 4: 3.1-fold (0.49 log units) below, outside the stated range (above it).
By their numbers in this assay, from the lowest: compounds 1, 2 and 3 (each within the scatter of the next); then compound 4.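

In this assay, going by these compounds alone, exchanges on the aromatic ring of the benzyl group had left the numbers within the scatter, but replacing the whole 4-chlorobenzyl group on the amine nitrogen with cyclopropyl gives the first step beyond it (a 3.7-fold higher number from compound 3 to compound 4 (0.56 log units; beyond the scatter)). The same replacement reads beyond the scatter against the other two benzyl compounds, both for 4-fluorobenzyl (a 4.5-fold higher number from compound 2 to compound 4 (0.65 log units; beyond the scatter)) and for 4-methoxybenzyl (a 6.5-fold higher number from compound 1 to compound 4 (0.81 log units; beyond the scatter)), so among these four compounds the choice of group on this nitrogen counts for more than the choice of methoxy, fluoro or chloro on the ring. No measurement is at hand that would explain this difference.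

The compounds shown leave open whether the aromatic ring itself or simply the larger group matters here, a question on which cyclohexylmethyl or a longer chain on the same nitrogen would bear. They also leave open how an unsubstituted benzyl group or a pyridylmethyl group would read on this scale, and whether a smaller group such as methyl would follow cyclopropyl.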